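The compounds below may be only part of what the source reports. "The series", "measured", "known", "first", "only" and "open" are said of these compounds alone.

Of the compounds shown here, two have been tested so far. Compound 1, `CCC(=O)Nc1ccc(-c2nc3cc(C(F)(F)F)ccc3n2C2CCCCC2)cc1`, gives 15000 nM in an ADME assay on BHK cells (Mesocricetus auratus) for cytotoxicity, read by MTT assay, with a stated time of 96 h; on this read-out lower numbers stand for higher toxicity in this test and higher numbers for lower toxicity in this test. Compound 2, `O=[N+]([O-])c1ccc(-c2nc3cc(C(F)(F)F)ccc3[nH]2)cc1`, gives 18000 nM in the same test, which makes it the higher of the two numbers, though the gap to compound 1 lies within the scatter of repeated measurements, so the two compounds cannot be told apart on this read-out. Compound 3, `CCC(=O)Nc1ccc(-c2nc3cc(C(F)(F)F)ccc3[nH]2)cc1`, has not yet been measured. It is derived from compound 2 by a single change: propanoylamino in place of nitro on an aromatic carbon. Among the compounds with values here, no measured pair shows this exact change, so its effect is not known from the data. Given that compound 1 and compound 2 sit so close to each other, a step from compound 2 to compound 3 of a 1.1-fold lower number from compound 2 to compound 3 (0.05 log units; within the scatter) is expected, that is, nothing beyond the scatter in either direction. Compound 3 is therefore estimated at 16000 nM, with a likely range from 7000 nM to 36000 nM.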

Compound 3, half-maximal cytotoxic concentration: 100000 nM
Compound 3: the middle estimate sits 6.3-fold (0.80 log units) below what was measured, and the stated range ends below it.
By their numbers in this assay, from the lowest: compounds 1 and 2 (each within the scatter of the next); then compound 3.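

In this assay, propanoylamino in place of nitro on an aromatic carbon, para to a large group, gives a 5.6-fold higher number from compound 2 to compound 3 (0.74 log units; beyond the scatter), so the group at this position does move the number when the aromatic nitrogen carries hydrogen. Hydrogen in place of cyclohexyl on that aromatic nitrogen, with propanoylamino kept, gives a 6.7-fold higher number from compound 1 to compound 3 (0.82 log units; beyond the scatter), so each of these two single changes goes beyond the scatter, which the earlier two compounds, differing in two places, could not show. Nothing at hand offers a reason for either step.

The compounds shown leave open whether a shorter acetylamino group or a plain amine at this position would give a similar number to propanoylamino. They also leave open whether a small methyl on the aromatic nitrogen would behave like hydrogen or like cyclohexyl.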